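Ester analogues on a shared core: predicting a nitro variant

A few compounds are considered here, and "the series" means these few. Any claim that something is new, unique, unknown or untested is made for them only; others in the source may bear on it.

Compound 1 `COc1cccc(C(=O)Oc2cc3c(cc2C)[C@@H](C(C)C)CC=C3C)c1` gives 11.9% in a functional assay on MCF7 cells (Homo sapiens) for antiproliferative activity, read by sulforhodamine B assay, with a stated time of 48 h, tested at 50 uM; a higher number here means more inhibition at the concentration tested (going by the name of the read-out), a lower number less inhibition.
Compound 2 `CC1=CC[C@H](C(C)C)c2cc(C)c(OC(=O)c3ccc(C)cc3)cc21` gives 65%.
Compound 3 `Cc1cc2c(C(C)C)ccc(C)c2cc1OC(=O)c1cccc(C(F)(F)F)c1` gives 41.5%.

Compound 2 stands highest of the three in this assay; compound 3 comes nearest, and compound 1 lies furthest off. Going by the values given here, the only one-place step measured is a number 53.1 percentage points higher from compound 1 to compound 2 (beyond the scatter), a large rise. Compound 4 `CC1=CC[C@H](C(C)C)c2cc(C)c(OC(=O)c3ccc([N+](=O)[O-])cc3)cc21` keeps the core of compound 2 and differs by nitro in place of methyl on an aromatic carbon. Among the compounds with values here, no measured step exchanges a nitro for a methyl, so the rise from compound 1 to compound 2 shows only that the group on this ring can shift the read-out strongly, while compound 3 with trifluoromethyl gives an intermediate value. The step is expected to be a number 20 percentage points lower from compound 2 to compound 4 (beyond the scatter), and compound 4 is estimated at 45%, ranging from 20% to 70%.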

Compound 4, a percentage reported as inhibition, at one concentration (the size of the read-out at that concentration, not a potency): 72.9%
The estimate for compound 4 lay 27.9 percentage points below the measured number, outside the stated range (above it).
By their numbers in this assay, from the lowest: compound 1; then compound 3; then compounds 2 and 4 (each within the scatter of the next).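

Exchanging methyl for nitro on this aromatic carbon gives a number 7.9 percentage points higher from compound 2 to compound 4 (within the scatter) in this assay, so this assay does not separate the two groups at this place, although one is a single carbon and the other has three heavy atoms. The step of a number 61 percentage points higher from compound 1 to compound 4 (beyond the scatter) shows that the 4-nitrophenyl ester, like the 4-methylphenyl ester, stands far from the 3-methoxyphenyl ester. No available measurement accounts for this result.

Going by these compounds, whether an amine or a carboxylic acid on the same aromatic carbon would give a similar number remains open. Potency also remains open, as these numbers come from a single concentration.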